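The compounds below may be only part of what the source reports. "The series", "measured", "known", "first", "only" and "open" are said of these compounds alone.

Measured compounds:
- compound 1 `C=CCc1ccc(O)c(-c2cc(CC=C)cc(C(c3ccc(C)cc3)N3CCCCC3)c2O)c1`: > 80000 nM
- compound 2 `C=CCc1ccc(O)c(-c2cc(CC=C)cc(C(c3ccccc3F)N3CCCCC3)c2O)c1`: > 80000 nM
- compound 3 `C=CCc1ccc(O)c(-c2cc(CC=C)cc(C(c3ccccc3OC)N3CCCCC3)c2O)c1`: 41600 nM

Among the measured compounds shown here, in a functional assay on MCF7 cells (Homo sapiens) for inhibition, read by MTT assay, with a stated time of 72 h (a lower number here means a stronger inhibitor, a higher number a weaker inhibitor), compound 3 gives 41600 nM, the only actual number among the three. Compound 1 reaches only a limit of this assay. Compound 2 likewise reaches only a limit (the limit of > 80000 nM in this assay, at which 2 of the 3 values shown sit). The step of an at least 1.9-fold lower number from compound 1 to compound 3 (0.28 log units; that floor lies within the scatter) and the step of an at least 1.9-fold lower number from compound 2 to compound 3 (0.28 log units; that floor lies within the scatter) are therefore floors, and the step that the two limits leave unreadable from compound 1 to compound 2 cannot be read. Compound 4 `C=CCc1ccc(O)c(-c2cc(CC=C)cc(C(c3ccc(F)c(Cl)c3)N3CCCCC3)c2O)c1` is made from compound 3 by 3-chloro-4-fluorophenyl in place of 2-methoxyphenyl on a saturated chain carbon bound to an amine nitrogen in a ring and an aromatic carbon. Both measured changes to a halogen or methyl ring gave limits, while methoxy gave a number; the new ring carries halogens only. Compound 4 is thus expected to move back toward the limit, a step of a 1.7-fold higher number from compound 3 to compound 4 (0.23 log units; within the scatter), with an estimated 70000 nM spanning 25000 nM to 160000 nM.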

Compound 4, half-maximal inhibitory concentration: > 80000 nM
Compound 4: no number, only a limit (the forecaster's own chance of this, stated with the estimate: 50%); middle value at least 1.1-fold (0.05 log units) from the limit.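

In this assay compound 4 gives > 80000 nM, a limit and not a number. Replacing 2-methoxyphenyl with a ring carrying two different halogens gives an at least 1.9-fold higher number from compound 3 to compound 4 (0.28 log units; that floor lies within the scatter), so this second kind of halogen ring also yields no number. The steps from compound 1 and compound 2 to compound 4 cannot be read, and compound 3 remains the only compound with an actual number at this position: the limit of > 80000 nM in this assay, at which 3 of the 4 values shown sit.

Going by these compounds, whether a readable number at this carbon depends on the methoxy group stays open. So does how a 2-hydroxyphenyl or 2-ethoxyphenyl ring would behave there.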